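3-Nitrophenyl in place of 4-hydroxyphenyl

A few compounds are considered here, and "the series" means these few. Any claim that something is new, unique, unknown or untested is made for them only; others in the source may bear on it.

In a functional assay on HT-29 cells (Homo sapiens) for cytotoxicity, read by sulforhodamine B assay (on this read-out lower numbers stand for stronger inhibition of growth and higher numbers for weaker inhibition of growth), compound 1 `COc1ccc(/C=N\NC(=S)NC(C)(C)CCC[C@](C)(O)[C@@H]2CC=C(C)CC2)cc1` gives 35200 nM and compound 2 `CC1=CC[C@@H]([C@@](C)(O)CCCC(C)(C)NC(=S)N/N=C\c2ccc(O)cc2)CC1` gives 31500 nM, so compound 2 stands level with compound 1 within the scatter. Compound 3 `CC1=CC[C@@H]([C@@](C)(O)CCCC(C)(C)NC(=S)N/N=C\c2cccc([N+](=O)[O-])c2)CC1` has 3-nitrophenyl in place of 4-hydroxyphenyl on a carbon with a double bond to nitrogen. Within the data shown here, the one measured step, a 1.1-fold lower number from compound 1 to compound 2 (0.05 log units; within the scatter), puts hydrogen in place of methyl on an oxygen on an aromatic ring and stays within the scatter. Among the measured compounds shown here, no compound with 3-nitrophenyl has been measured, so no direction can be argued from the data. The expected step in this assay is a 1.1-fold lower number from compound 2 to compound 3 (0.02 log units; within the scatter), nothing beyond the scatter. For compound 3 the estimated value is 30000 nM, with an expected range of 11000 nM to 70000 nM.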

Compound 3, concentration for total growth inhibition: 57100 nM
Estimate against measurement, compound 3: 1.9-fold (0.28 log units) below; measured number inside the range.
By their numbers in this assay, from the lowest: compounds 2, 1 and 3 (each within the scatter of the next).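

In this assay the steps of a 1.8-fold higher number from compound 2 to compound 3 (0.26 log units; within the scatter) and a 1.6-fold higher number from compound 1 to compound 3 (0.21 log units; within the scatter) extend the picture at this carbon with a double bond to nitrogen: replacing the whole substituted phenyl, and not only a methyl on its oxygen, still stays within the scatter. Compounds 1, 2 and 3 therefore stand level, and the position has yet to show a step beyond the scatter. No measured data bear on the reason for this. From the compounds shown here alone, whether an aminophenyl, a carboxyphenyl or a longer chain at this carbon would move the number beyond the scatter stays open.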